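The compounds below may be only part of what the source reports. "The series", "measured", "known", "first", "only" and "open" are said of these compounds alone.

Measured compounds:
Compound 1 `CC(=O)Nc1nc2ccnc(-c3cccc(NS(=O)(=O)c4ccc(C)cc4)c3)n2n1` – 1600 nM
Compound 2 `Cc1ccc(S(=O)(=O)Nc2cccc(-c3nccc4nc(N)nn34)c2)cc1` – 1500 nM
Compound 3 `CC(=O)Nc1nc2c(C)cnc(-c3cccc([N+](=O)[O-])c3)n2n1` – 11000 nM

These three were tested in a functional assay (Homo sapiens); on this read-out higher numbers stand for weaker inhibition and lower numbers for stronger inhibition. Compound 1 and compound 2 share a core and differ only in one place: hydrogen in place of acetyl on a nitrogen on an aromatic ring. That change gave a 1.1-fold lower number from compound 1 to compound 2 (0.03 log units; within the scatter), so the two values cannot be told apart. Compound 3 differs from compound 1 in more than this; the difference between the two cores is not broken down here. Compound 3 gives the highest of the three numbers in this assay, beyond the scatter from both compound 1 and compound 2.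

Compound 4 `Cc1cnc(-c2cccc([N+](=O)[O-])c2)n2nc(N)nc12` has not yet been measured. It stands to compound 3 as compound 2 stands to compound 1, the same change: hydrogen in place of acetyl on a nitrogen on an aromatic ring. Because the earlier case gave a 1.1-fold lower number from compound 1 to compound 2 (0.03 log units; within the scatter), a step of a 1.1-fold lower number from compound 3 to compound 4 (0.04 log units; within the scatter) is expected here, with the number for compound 3 as the starting point. Compound 4 is therefore expected to give 10000 nM, with a likely range from 4000 nM to 25000 nM.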

Compound 4, half-maximal inhibitory concentration: 8700 nM
Compound 4: middle estimate off by 1.1-fold (0.06 log units), on the high side, and the stated range covers the measured number.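

In this assay, putting hydrogen in place of acetyl, acetamido to amino, gave a 1.3-fold lower number from compound 3 to compound 4 (0.10 log units; within the scatter). Set beside the earlier case, the change carried from one core to the other with no difference that can be told apart: the same change on two cores in this assay, a 1.1-fold lower number (0.03 log units; within the scatter) from compound 1 to compound 2 and a 1.3-fold lower number (0.10 log units; within the scatter) from compound 3 to compound 4, 1.2-fold (0.07 log units) apart, within the scatter of two such steps. This shows that the two members of each pair cannot be told apart on these two cores, but it does not show that the same would hold on any other core.

The compounds shown leave open what a longer acyl chain, such as propionyl, or a benzoyl group on this nitrogen would give. They also leave open how the change would read with a carboxylic acid in place of the nitro group.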